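From benzyl to 3-methoxybenzyl at an assay limit

The compounds below may be only part of what the source reports. "The series", "measured", "known", "first", "only" and "open" are said of these compounds alone.

Measured in a functional assay on Jurkat cells (Homo sapiens) for inhibition, read by CCK-8 assay, with a stated time of 48 h; on this read-out higher numbers stand for weaker inhibition of growth and lower numbers for stronger inhibition of growth 
Compound 1 `Cc1ccccc1Nc1nc(Nc2ccccn2)ncc1Cl` gives 20100 nM 
Compound 2 `Cc1ccccc1Nc1nc(Nc2ccc(N3CCN(C)CC3)cc2)ncc1Cl` gives 13700 nM 
Compound 3 `CN1CCN(c2ccc(Nc3ncc(Cl)c(NCc4ccccc4)n3)nc2)CC1` gives > 100000 nM 

The values of compound 1 and compound 2 lie within the usual scatter of each other. In this assay compound 3 gives > 100000 nM, and this is a limit, not a number. It therefore has no exact place on the scale.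

Compound 4 `COc1cccc(CNc2nc(Nc3ccc(N4CCN(C)CC4)cn3)ncc2Cl)c1` differs from compound 3 by one change, (methoxy in place of hydrogen on an aromatic carbon), which is methoxy in place of hydrogen on an aromatic carbon, meta to a large group. Going by the values given here, no measured step shows what this change does, so only a modest shift toward stronger inhibition of growth is expected, and compound 4 may well reach the same limit. The step expected is an at least 1.6-fold lower number from compound 3 to compound 4 (0.22 log units; that floor lies within the scatter), a small one. For compound 4 the estimated value in this assay is 60000 nM, with an expected range from 25000 nM to 100000 nM.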

Compound 4, concentration for 50% growth inhibition: 73400 nM
Compound 4: middle estimate off by 1.2-fold (0.09 log units), on the low side; the range from low to high includes it.
By their numbers in this assay, from the lowest: compounds 2 and 1 (each within the scatter of the next); then compound 4. At a limit, above all of these: compound 3.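

With methoxy in place of hydrogen on an aromatic carbon, meta to a large group, a compound carrying the substituted benzylamino group gains a real place on the scale of this assay, where compound 4 gives 73400 nM. The change reads as an at least 1.3-fold lower number from compound 3 to compound 4 (0.13 log units; that floor lies within the scatter), and that floor is all that can be said of its size. The value of compound 3 is a limit and not a number, so the true step may be larger: the limit of > 100000 nM in this assay, at which 1 of the 4 values shown sits.

Going by these compounds, whether an amine, a hydroxyl or a carboxylic acid at this same place would shift the number further remains open. On these data alone, it is also open whether methoxy on another carbon of that ring would give a similar value, and whether the same change would act alike on a compound whose parent has a measurable number.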